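From Isopropylcarbonyl to 4-Bromobenzyl on the Ring Nitrogen

The source may report more compounds than this note shows. Statements on the series, on what has been measured and on what is new or still open speak of the compounds shown alone.

Measured in an assay on isolated protein for inhibition of Fatty-acid amide hydrolase 1 (Homo sapiens); a higher number here means a weaker inhibitor, a lower number a stronger inhibitor:
compound 1 `CC(C)C(=O)N1CCC(CCCC(=O)c2ncco2)CC1` gives 250 nM
compound 2 `Cc1ccc(CN2CCC(CCCC(=O)c3ncco3)CC2)cc1` gives 400 nM
compound 3 `O=C(CCCC1CCN(Cc2cccc(Br)c2)CC1)c1ncco1` gives 10 nM

Compound 1 stands second highest of these three numbers. The step of a 1.6-fold higher number from compound 1 to compound 2 (0.20 log units; within the scatter) changes little, whereas the step of a 25-fold lower number from compound 1 to compound 3 (1.40 log units; beyond the scatter) is a large drop; comparing the two benzyl groups directly, a 40-fold lower number from compound 2 to compound 3 (1.60 log units; beyond the scatter) shows that a 3-bromophenyl rather than a 4-methylphenyl makes the difference. Compound 4 `O=C(CCCC1CCN(Cc2ccc(Br)cc2)CC1)c1ncco1` differs from compound 1 in one place: 4-bromobenzyl in place of isopropylcarbonyl on an amine nitrogen in a ring. It carries 4-bromobenzyl where compound 3 carries 3-bromobenzyl, so the step from compound 1 to compound 3 bears most on it, tempered by the flat step from compound 1 to compound 2. A drop in this assay is therefore expected for compound 4, probably smaller than that seen for compound 3, estimated as a 4.2-fold lower number from compound 1 to compound 4 (0.62 log units; beyond the scatter). Compound 4 is expected to give about 60 nM, within 12 nM to 300 nM.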

Compound 4, half-maximal inhibitory concentration: 45 nM
Estimate against measurement, compound 4: 1.3-fold (0.12 log units) above; measured number inside the range.
By their numbers in this assay, from the lowest: compound 3; then compound 4; then compounds 1 and 2 (each within the scatter of the next).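

In this assay, the place of the bromine on the benzyl group matters, since a 4.5-fold higher number from compound 3 to compound 4 (0.65 log units; beyond the scatter) separates two groups that differ only in that place. Bromo in place of methyl also counts, with an 8.9-fold lower number from compound 2 to compound 4 (0.95 log units; beyond the scatter), and so 4-bromobenzyl still improves on isopropylcarbonyl on the ring nitrogen, with a 5.6-fold lower number from compound 1 to compound 4 (0.74 log units; beyond the scatter). No measurement here accounts for either effect. Still open, on these data alone, is whether chloro or methoxy in place of bromo, or a plain benzyl group, would give numbers nearer compound 3 or compound 4.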